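Hydroxy Added to the Ethylamino Chain of Compound 1

The source may hold more compounds than are shown below. What is called first, only, known or untested is meant among the compounds shown, and "the series" means these compounds.

Measured so far:
compound 1, `CCNc1nccc2c1ncn2C1O[C@H](CO)[C@@H](O)[C@H]1O`, gives 4%
compound 2, `OC[C@H]1O[C@@H](n2cnc3c(SCc4ccccc4)nccc32)C[C@@H]1O`, gives 18%

Of the compounds shown here, two have been measured in a functional assay (Homo sapiens) for inhibition of Nucleic Acid, tested at 100 uM; on this read-out lower numbers stand for less inhibition and higher numbers for more inhibition at the one concentration tested (going by the name of the read-out). Compound 1 gives 4%, the lower of the two numbers. Compound 2 gives 18%, a number higher than that of compound 1 by a gap beyond the usual scatter. The two differ in several places at once, so only their two values can be compared and no single change can be credited with the gap.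

Compound 3, `OCCNc1nccc2c1ncn2C1O[C@H](CO)[C@@H](O)[C@H]1O`, differs from compound 1 in one place: hydroxy in place of hydrogen on a saturated chain carbon, two bonds along the chain from a nitrogen on an aromatic ring. Among the measured compounds shown here, no measured pair shows this same change, so the size of the step has to be guessed. A change this small on the side chain is expected to move the read-out only a little: the expected step of a number 2 percentage points higher from compound 1 to compound 3 (within the scatter) lies within the usual scatter. Compound 3 is therefore estimated at 6%, in a range from 0% to 20%.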

Compound 3, a percentage reported as inhibition, at one concentration (the size of the read-out at that concentration, not a potency): 0%
Beside the measured number, compound 3's estimate is 6 percentage points above it, within the range that was stated.
By their numbers in this assay, from the lowest: compounds 3 and 1 (each within the scatter of the next); then compound 2.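

Among the compounds shown here, compounds 1 and 3 are the first pair here that differ in one place only, so a single change can now be read on its own. In this assay the swap of ethylamino to (2-hydroxyethyl)amino gives a number 4 percentage points lower from compound 1 to compound 3 (within the scatter) and so cannot be told apart from no change at all: hydroxy at this spot on the chain brings no gain in inhibition that this test can detect. Nothing available offers a reason for this result.

Going by these compounds, whether an amine or a carboxylic acid at the same chain carbon, or a longer chain, would shift the number beyond the scatter remains open. The several differences between compound 1 and compound 2 also remain unsorted, so none of them can yet be credited with the number of compound 2.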